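The compounds below may be only part of what the source reports. "The series", "measured", "known", "first", "only" and "open" are said of these compounds alone.

Measured compounds, all in an assay for activation of interferon regulatory factor 3 (Homo sapiens), read by a luciferase reporter, with a stated time of 20 h; on this read-out lower numbers stand for an effect already at smaller amounts and higher numbers for an effect only at larger amounts of compound:
- compound 1 `CCCn1c(NC(=O)c2ccc3ccccc3n2)nc2cc(C(N)=O)cc(OC)c21`: > 100000 nM, a limit of the assay
- compound 2 `CCCn1c(NC(=O)CCc2ccccc2)nc2cc(C(N)=O)cc(OC)c21`: > 100000 nM, a limit of the assay
- compound 3 `COc1cc(C(N)=O)cc2nc(NC(=O)c3ccc4ccccc4n3)n(CCCNC(=O)OCc3ccccc3)c12`: > 100000 nM, a limit of the assay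

Compound 3 stands at the limit in this assay, and every other value in the series sits there too (the limit of > 100000 nM in this assay, at which 3 of the 3 values shown sit). The step that the two limits leave unreadable from compound 1 to compound 2 and the step that the two limits leave unreadable from compound 1 to compound 3 both run between two limits, so neither shows a direction or a size.

Compound 4 `COc1cc(C(N)=O)cc2nc(NC(=O)c3cc4ccccc4n3C)n(CCCNC(=O)OCc3ccccc3)c12` differs from compound 3 in one place: 1-methyl-1H-indol-2-yl in place of quinolin-2-yl on a carbonyl carbon. Within the data shown here, none of the measured steps touches the carbonyl substituent in a readable way; the only change made there, from compound 1 to compound 2, is unreadable between limits, so nothing shows what exchanging a quinolin-2-yl for a 1-methyl-1H-indol-2-yl does.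

With no readable step to lean on, compound 4 is expected to behave like compound 3 and most likely to return a limit as well. The estimated step of a number no higher from compound 3 to compound 4 (the limit leaves the size open) is therefore expected to be none beyond the scatter. For compound 4 the estimate is 100000 nM, with a range from 20000 nM to 300000 nM.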

Compound 4, half-maximal effective concentration: > 100000 nM
Compound 4 ended at the assay's limit; the forecaster's own chance of this, stated with the estimate: 75%; the middle value lies on the limit itself.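

In this assay compound 4 gives > 100000 nM, which is a limit of the assay. No step can be read from compound 3 to compound 4, and the series as a whole offers no value to compare: the limit of > 100000 nM in this assay, at which 4 of the 4 values shown sit.

The compounds shown leave open whether any change on the carbonyl carbon or the chain affects this read-out.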